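Hydrazone series: fluoro for bromo on the phenol ring

The source may hold more compounds than are shown below. What is called first, only, known or untested is meant among the compounds shown, and "the series" means these compounds.

Measured compounds:
- compound 1 `Cc1c(C(=O)N/N=C\c2cccc(O)c2O)oc2cccc(O)c12`, in a functional assay on PC-3 cells (Homo sapiens) for inhibition (on this read-out lower numbers stand for stronger inhibition and higher numbers for weaker inhibition), compound 1 gives 12200 nM
- compound 2 `Cc1c(C(=O)N/N=C\c2ccccc2O)oc2cccc(O)c12`, in this assay compound 2 gives 8350 nM
- compound 3 `Cc1c(C(=O)N/N=C\c2cccc(Br)c2O)oc2cccc(O)c12`, in this assay compound 3 gives 16600 nM

Compound 3 carries the highest of the three numbers in this assay, but the steps of a 1.4-fold higher number from compound 1 to compound 3 (0.13 log units; within the scatter) and a 2.0-fold higher number from compound 2 to compound 3 (0.30 log units; within the scatter) are both within the scatter, so no order among the three is established. The substituent ortho to the hydroxy group has so far been hydroxy, hydrogen or bromo, and the step of a 1.5-fold lower number from compound 1 to compound 2 (0.16 log units; within the scatter) is likewise within the scatter.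

Compound 4 `Cc1c(C(=O)N/N=C\c2cccc(F)c2O)oc2cccc(O)c12` differs from compound 3 only in this position: fluoro in place of bromo on an aromatic carbon. Every measured exchange at this carbon has stayed inside the scatter, so the expectation for a fourth substituent there is no step beyond the scatter in this assay, with the expected direction a 1.3-fold lower number from compound 3 to compound 4 (0.11 log units; within the scatter) left open within that band.

Compound 4 is therefore estimated at 13000 nM, with a range from 6000 nM to 28000 nM in this assay.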

Compound 4, half-maximal inhibitory concentration: 12700 nM
The estimate for compound 4 lay 1.0-fold (0.01 log units) above the measured number; measured number inside the range.
By their numbers in this assay, from the lowest: compounds 2, 1, 4 and 3 (each within the scatter of the next).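

In this assay, a fourth substituent ortho to a hydroxy group, fluoro, gives no step beyond the scatter against bromo (a 1.3-fold lower number from compound 3 to compound 4 (0.12 log units; within the scatter)), hydrogen (a 1.5-fold higher number from compound 2 to compound 4 (0.18 log units; within the scatter)) or hydroxy (a 1.0-fold higher number from compound 1 to compound 4 (0.02 log units; within the scatter)). Together with the earlier steps, this places all four compounds in one band: exchanges among hydroxy, hydrogen, bromo and fluoro at this aromatic carbon separate none of them, and no order among these substituents can be read. No available measurement bears on why this position is so insensitive across these four compounds.

From the compounds shown here alone, it remains open whether a different kind of group at this carbon, such as an amine, a carboxylic acid or a longer chain such as butoxy, would produce a step beyond the scatter in this assay. Going by these compounds, it is also open whether exchanges at this carbon would stay within the scatter if the neighbouring hydroxy group gave way to a methoxy group or an amine, since that hydroxy group is common to all four compounds.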